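The source may hold more compounds than are shown below. What is called first, only, known or untested is meant among the compounds shown, and "the series" means these compounds.

Measured so far in an assay on HEK293 cells for inhibition of acid ceramidase (Rattus norvegicus), read by LC-MS, with a stated time of 30 min; a lower number here means a stronger inhibitor, a higher number a weaker inhibitor:
- compound 1 `CCCCCCNC(=O)n1cc(C)c(=O)[nH]c1=O`: 1460 nM
- compound 2 `CCCCCCNC(=O)n1cc(Cl)c(=O)[nH]c1=O`: 67 nM

Compound 2 holds the lowest number of the two in this assay. Among the measured compounds shown here, the only measured step, a 22-fold lower number from compound 1 to compound 2 (1.34 log units; beyond the scatter), concerns a different change at the same aromatic carbon. Compound 3 `CCCCCCNC(=O)n1cc(C(F)(F)F)c(=O)[nH]c1=O` differs from compound 2 by trifluoromethyl in place of chloro on an aromatic carbon. For the measured compounds named here, no measured step covers this exchange, so the large size of the step from compound 1 to compound 2 is only a loose guide. In this assay compound 3 is expected to stay near compound 2, at 100 nM (range 30 nM to 400 nM), an expected step of a 1.5-fold higher number from compound 2 to compound 3 (0.17 log units; within the scatter).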

Compound 3, half-maximal inhibitory concentration: 12 nM
Compound 3: middle estimate off by 8.3-fold (0.92 log units), on the high side; measured number outside the range, below it.
By their numbers in this assay, from the lowest: compound 3; then compound 2; then compound 1.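

In this assay this aromatic carbon accepts more than a single heavy atom: trifluoromethyl, with 4 heavy atoms against 1 for chloro, gives a 5.6-fold lower number from compound 2 to compound 3 (0.75 log units; beyond the scatter) and does not lose ground. Against methyl the exchange gives a 120-fold lower number from compound 1 to compound 3 (2.09 log units; beyond the scatter), so the three groups now rank trifluoromethyl, chloro, methyl, from the lowest number, with every step beyond the scatter. Nothing on hand accounts for this order. Open, going by these compounds, is where other groups on this carbon, such as a nitrile or bromine, would fall. Also open, on these data alone, is whether the order holds with a longer chain on the shared core.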